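The source may report more compounds than this note shows. Statements on the series, on what has been measured and on what is new or still open speak of the compounds shown alone.

Of the compounds shown here, three built on a shared core have been tested in an in vitro assay on BTI-TN-5B1-4 cells for inhibition of Amine oxidase [flavin-containing] A (Homo sapiens), read by Amplex Red, with a stated time of 15 min, tested at 100 uM; on this read-out higher numbers stand for more inhibition at the one concentration tested (going by the name of the read-out) and lower numbers for less inhibition. Compound 1 `N#Cc1ccc(-c2csc(N/N=C\c3ccncc3)n2)cc1` is reported as "not active" (no number reported), without a number attached. Compound 2 `N#Cc1ccc(-c2csc(N/N=C\c3cccc4ccccc34)n2)cc1` gives 40%. Compound 3 `O=[N+]([O-])c1ccc(-c2csc(N/N=C\c3ccco3)n2)cc1` gives 40%, so compound 2 stands level with compound 3 at the digits shown, the two values lying within the usual scatter of this measurement.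

Compound 4 `O=[N+]([O-])c1ccc(-c2csc(N/N=C\c3cccc4ccccc34)n2)cc1` has not yet been measured in this assay. It differs from compound 2 in one place: nitro in place of cyano on an aromatic carbon. Within the data shown here, no pair of measured compounds differs by this change alone, so no measured step is available for it. Compound 3 also carries a nitro group, on a different partner ring, and its reading matches that of compound 2. On that basis the step from compound 2 to compound 4 is expected to be no change at the digits printed from compound 2 to compound 4 (within the scatter), that is, no change beyond the scatter in either direction. Compound 4 is therefore estimated to give 40% in this assay, within a range from 25% to 55%.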

Compound 4, a percentage reported as inhibition, at one concentration (the size of the read-out at that concentration, not a potency): "not active" (no number reported)
Nothing numeric was reported for compound 4; there is nothing to compare the estimate with.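

In this assay, among these compounds, compound 2 gives 40% and compound 4 is reported as "not active" (no number reported) so no step from compound 2 to compound 4 can be read. The compounds shown leave open how far the change from 4-cyanophenyl to 4-nitrophenyl moves inhibition. Nothing shown here explains the result for compound 4.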